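This account rests on a few compounds, and the source may have more. Where it says the series, first, only, none or still open, it means among the compounds named here.

Cytotoxicity in an ADME assay on L02 cells (Homo sapiens) for cytotoxicity, read by MTT assay, with a stated time of 72 h (on this read-out higher numbers stand for weaker inhibition and lower numbers for stronger inhibition), measured compounds:

compound 1 `CC/C=C/C(=O)Nc1cccc(Oc2nc(Nc3cccc(OC)c3)nc3c2CSCC3)c1`: > 50000 nM, a limit of the assay.
compound 2 `CCC/C=C/C(=O)Nc1cccc(Oc2nc(Nc3cccc(OC)c3)nc3c2CSCC3)c1`: > 50000 nM, a limit of the assay.
compound 3 `C/C=C/C(=O)Nc1cccc(Oc2nc(Nc3ccc(OC)nc3)nc3c2CSCC3)c1`: > 50000 nM, a limit of the assay.

All three values sit at the limit of > 50000 nM in this assay, at which 3 of the 3 values shown sit. The change from compound 1 to compound 2 is methyl in place of hydrogen on a saturated chain carbon, two bonds along the chain from a double-bonded chain carbon, and its step in this assay is a step that the two limits leave unreadable from compound 1 to compound 2. Compound 4 `CC/C=C/C(=O)Nc1cccc(Oc2nc(Nc3ccc(OC)nc3)nc3c2CSCC3)c1` is not yet measured in this assay and differs from compound 3 by methyl in place of hydrogen on a saturated chain carbon bound to a double-bonded chain carbon. The two places are not the same in words: in compound 4 the methyl enters on a saturated chain carbon bound to a double-bonded chain carbon, in compound 2 on a saturated chain carbon two bonds along the chain from a double-bonded chain carbon, so this is the same kind of change, not the same. The difference between the core of compound 3 and the core of compound 1 is not broken down here. The expectation rests on compound 3, whose value is a limit, > 50000 nM, and on the step that the two limits leave unreadable from compound 1 to compound 2, which the limits leave unreadable. For compound 4 the expected value is 70000 nM, between 30000 nM and 200000 nM, with an expected step that the limit leaves unreadable from compound 3 to compound 4.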

Compound 4, half-maximal inhibitory concentration: > 50000 nM
Compound 4: no number, only a limit; the forecaster's own chance of this, stated with the estimate: 85%; the middle value is on the limit's open side.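

Compound 4, like compound 1 and compound 3, gives only a limit, so no new step can be read from compound 3 to compound 4 or from compound 1 to compound 4: the limit of > 50000 nM in this assay, at which 4 of the 4 values shown sit.
As far as these compounds go, whether the methyl or the 6-methoxypyridin-3-yl change alters cytotoxicity at all stays open.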